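Solubility notes on the triazolyl-quinazoline series, compound 3 to 4

The compounds below may be only part of what the source reports. "The series", "measured", "known", "first", "only" and "open" are said of these compounds alone.

Three compounds have numbers in a physicochemical assay for solubility, in phosphate buffer, with a stated time of 18 h, at pH 7.4; a higher number here means a more soluble compound, a lower number a less soluble compound. Compound 1 `Nc1nc(-c2ccccc2)nn1-c1ncnc2ccccc12` gives 1000 nM. Compound 2 `Nc1nc(-c2ccc(Cl)cc2)nn1-c1ncnc2cc(Cl)ccc12` gives 5000 nM in this assay. Compound 3 `COc1cc2ncnc(-n3nc(-c4ccccn4)nc3N)c2cc1OCCCN(C)C` gives 53000 nM in this assay, the highest of the three numbers shown: the nearest is compound 2 and the furthest is compound 1, and both gaps lie beyond the scatter. Compound 4 `COc1cc2ncnc(-n3nc(-c4ccccn4)nc3N)c2cc1OCCCNC(=O)C(F)(F)F` has not been measured in this assay. The change from compound 3 to compound 4 is ((trifluoromethyl)carbonyl)amino in place of dimethylamino on a saturated chain carbon, three bonds along the chain from an oxygen on an aromatic ring.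

For the measured compounds named here, no pair among the measured compounds differs in one place, so there is no measured step to lean on. The expectation for this assay rests on the numbers above and on the change described. Compound 4 is expected to give a lower number than compound 3, with the estimate 8000 nM and a range from 2000 nM to 30000 nM. The expected step of a 6.6-fold lower number from compound 3 to compound 4 (0.82 log units; beyond the scatter) is a fall beyond the scatter, leaving compound 4 still above compound 1 and near compound 2.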

Compound 4, solubility: 1000 nM
Estimate against measurement, compound 4: 8.0-fold (0.90 log units) above; the whole stated range lies above it.
By their numbers in this assay, from the lowest: compounds 1 and 4 (each within the scatter of the next); then compound 2; then compound 3.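

The series now has its first step in one place in this assay and it is a large one: the change gives a 53-fold lower number from compound 3 to compound 4 (1.72 log units; beyond the scatter) when ((trifluoromethyl)carbonyl)amino replaces dimethylamino on a saturated chain carbon, three bonds along the chain from an oxygen on an aromatic ring. With the rest of the structure held the same, this place on the chain clearly matters for the read-out, though the change brings in a hydrogen-bond donor, a double bond outside aromatic rings and more heavy atoms all at once, and one step does not separate them. No measurement shown bears on the reason for the step.

On these data alone, whether the fall belongs to the loss of dimethylamino or to the arrival of the new group stays open. A primary amine or a carboxylic acid on the same chain carbon, or a longer chain carrying dimethylamino, would help to separate the two.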